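Notes on the ethoxycarbonyl step to compound 4

This account rests on a few compounds, and the source may have more. Where it says the series, first, only, none or still open, it means among the compounds named here.

Measured in a functional assay on PC-3 cells (Homo sapiens) for antiproliferative activity, with a stated time of 48 h (on this read-out lower numbers stand for stronger inhibition and higher numbers for weaker inhibition), each entry a limit and not a number:
Compound 1 (`CCN(CC)c1ccc(-c2cccc(OC)c2)nn1`) gives > 25000 nM
Compound 2 (`CCN(CC)c1ccc(-c2cccc(C(F)(F)F)c2)nn1`) gives > 25000 nM
Compound 3 (`CCN(CC)c1ccc(-c2ccc(C#N)cc2)nn1`) gives > 25000 nM

Compound 2 stands at the limit of > 25000 nM in this assay, at which 3 of the 3 values shown sit, and has no readable number, only a limit. Compound 4 (`CCOC(=O)c1cccc(-c2ccc(N(CC)CC)nn2)c1`) carries ethoxycarbonyl in place of trifluoromethyl on an aromatic carbon, meta to a large group (ethoxycarbonyl in place of trifluoromethyl on an aromatic carbon). Among the compounds with values here, the one measured step that bears on this change is a step that the two limits leave unreadable from compound 1 to compound 2 and it offers no size to carry over. With no readable size from compound 2 or its neighbours, no step beyond the scatter is expected in this assay and a further limit is the likeliest report. The expected change is a step that the limit leaves unreadable from compound 2 to compound 4 and it should be read as an estimate resting on limits alone. For compound 4 the estimated value is 30000 nM with an expected range from 15000 nM to 60000 nM in this reading.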

Compound 4, half-maximal inhibitory concentration: > 25000 nM
Compound 4: only a limit was reported; the forecaster's own chance of this, stated with the estimate: 80%; the middle value does not contradict the limit.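

Compound 4 joins compound 1 and compound 2 in giving a limit and not a number, so no new step can be read for any of these pairs: the limit of > 25000 nM in this assay, at which 4 of the 4 values shown sit.

The compounds shown leave open whether methoxy, trifluoromethyl or ethoxycarbonyl on the shared core makes any difference in this assay; none of these compounds gives a readable number.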